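Taking a hydroxy from an inactive compound

The compounds below may be only part of what the source reports. "The series", "measured", "known", "first", "only" and "open" are said of these compounds alone.

In a functional assay on A549 cells (Homo sapiens) for cytotoxicity, read by MTT assay, with a stated time of 24 h (a higher number here means a weaker inhibitor, a lower number a stronger inhibitor), compound 3 `C/C=C(\C)C(=O)C[C@@H]1[C@@]2(C)[C@@H](O)CCC(C)(C)[C@]2(O)CC[C@@]1(C)O` gives > 10000 nM, which is a limit and not a number. Compound 1 `C[C@@H]1O[C@@]1(C)C(=O)C[C@H]1[C@](C)(O)CC[C@@]2(O)C(C)(C)CCC[C@]12C` gives > 10000 nM, also a limit. Compound 2 `C[C@H]1O[C@]1(C)C(=O)C[C@H]1[C@](C)(O)CC[C@@]2(O)C(C)(C)CCC[C@]12C` gives > 10000 nM, again a limit. This shared ceiling is the limit of > 10000 nM in this assay, at which 3 of the 3 values shown sit.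

Compound 4 `C/C=C(\C)C(=O)C[C@H]1[C@](C)(O)CC[C@@]2(O)C(C)(C)CCC[C@]12C` differs from compound 3 by hydrogen in place of hydroxy on a saturated ring carbon. Within the data shown here, the only measured step is a step that the two limits leave unreadable from compound 1 to compound 2, and what sets that pair apart is the fact that compounds 1 and 2 differ only in the configuration as drawn, so it gives no size for this change. Compound 3 gives > 10000 nM, a limit, so compound 4 is expected to remain weak in this assay. The expected step is a step that the limit leaves unreadable from compound 3 to compound 4. Compound 4 is estimated at 20000 nM, with an expected range of 6000 nM to 60000 nM.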

Compound 4, half-maximal inhibitory concentration: > 10000 nM
Compound 4: no number, only a limit; the forecaster's own chance of this, stated with the estimate: 80%; the middle value does not contradict the limit.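

Compound 4 gives > 10000 nM as a limit and not a number, so its steps from compound 1, compound 2 and compound 3 cannot be read: the limit of > 10000 nM in this assay, at which 4 of the 4 values shown sit. The compounds shown leave open whether hydrogen in place of hydroxy, or any other change among them, alters cytotoxicity at all.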